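Swapping the Aryl Group in a Weakly Cytotoxic Series

A few compounds are considered here, and "the series" means these few. Any claim that something is new, unique, unknown or untested is made for them only; others in the source may bear on it.

Three compounds were examined in a functional assay on MCF7 cells (Homo sapiens) for cytotoxicity, read by MTT assay, with a stated time of 72 h; on this read-out higher numbers stand for weaker inhibition and lower numbers for stronger inhibition. Compound 1 `COc1cc2ncnc(Nc3ccc(F)c(Cl)c3)c2cc1NC(=O)/C=C/c1ccccc1[N+](=O)[O-]` gives 36500 nM in this assay. Compound 2 `COc1cc(/C=C/C(=O)Nc2cc3c(Nc4ccc(F)c(Cl)c4)ncnc3cc2OC)cc(OC)c1` carries the change 3,5-dimethoxyphenyl in place of 2-nitrophenyl on a double-bonded chain carbon bound to a double-bonded chain carbon and in this assay compound 2 gives 38500 nM, so the step was a 1.1-fold higher number from compound 1 to compound 2 (0.02 log units; within the scatter). Compound 3 `O=C(/C=C/c1ccccc1[N+](=O)[O-])Nc1cc2c(Nc3ccc(F)c(Cl)c3)ncnc2cc1O[C@H]1CCOC1` differs from compound 1 in its core by oxolan-3-yl in place of methyl on an oxygen on an aromatic ring, and in this assay compound 3 gives 28400 nM, a step of a 1.3-fold lower number from compound 1 to compound 3 (0.11 log units; within the scatter). Within the data shown here, compound 4 `COc1cc(/C=C/C(=O)Nc2cc3c(Nc4ccc(F)c(Cl)c4)ncnc3cc2O[C@H]2CCOC2)cc(OC)c1` remains to be measured; it differs from compound 3 by 3,5-dimethoxyphenyl in place of 2-nitrophenyl on a double-bonded chain carbon bound to a double-bonded chain carbon, which is the same change as the one made from compound 1 to compound 2, here on the altered core. Resting on the earlier step of a 1.1-fold higher number from compound 1 to compound 2 (0.02 log units; within the scatter), the step of a 1.1-fold higher number from compound 3 to compound 4 (0.02 log units; within the scatter) is expected to be similarly small. Compound 4 is therefore estimated at 30000 nM in this assay, with a likely range from 15000 nM to 60000 nM.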

Compound 4, half-maximal inhibitory concentration: 30300 nM
Estimate against measurement, compound 4: 1.0-fold (0.00 log units) below; the measured number falls inside the stated range.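

In this assay, 3,5-dimethoxyphenyl in place of 2-nitrophenyl gave a 1.1-fold higher number from compound 3 to compound 4 (0.03 log units; within the scatter), and this step agrees with the one on the other core: the same change on two cores in this assay, a 1.1-fold higher number (0.02 log units; within the scatter) from compound 1 to compound 2 and a 1.1-fold higher number (0.03 log units; within the scatter) from compound 3 to compound 4, 1.0-fold (0.00 log units) apart, within the scatter of two such steps. Oxolan-3-yl in place of methyl on the oxygen gave a 1.3-fold lower number from compound 2 to compound 4 (0.10 log units; within the scatter), which likewise agrees with its earlier counterpart: the same change on two cores in this assay, a 1.3-fold lower number (0.11 log units; within the scatter) from compound 1 to compound 3 and a 1.3-fold lower number (0.10 log units; within the scatter) from compound 2 to compound 4, 1.0-fold (0.00 log units) apart, within the scatter of two such steps. Among these compounds, each change thus reads the same on both cores, but all four steps lie within the scatter, so this shows only that changes with no measurable effect stayed that way on these two cores, not that a change with a real effect would carry over.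

The compounds shown leave open whether a dimethylamino group in place of the aryl group, or a carboxylic acid on that ring, would shift the number beyond the scatter. They also leave open whether the agreement would hold in any other assay.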